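The source may hold more compounds than are shown below. What is called first, only, known or untested is meant among the compounds shown, and "the series" means these compounds.

Going by the values given here, in an ADME assay on HEL cells (Homo sapiens) for cytotoxicity, with a stated time of 3 days (on this read-out higher numbers stand for lower toxicity in this test and lower numbers for higher toxicity in this test), compound 1 `Cc1cc(-c2ccc(O)cc2)c2ncc(CSCCc3ccccc3)n2c1` gives 20 ug/mL, while compound 3 `Cc1cc(-c2cccs2)c2ncc(CSCCc3ccccc3)n2c1` gives 100 ug/mL; the step of a 5.0-fold higher number from compound 1 to compound 3 (0.70 log units; beyond the scatter) is the only single-point change with numbers on both sides. Compound 2 `Cc1cc(-c2ccc(C#N)cc2)cn2c(CSCCc3ccccc3)cnc12` stands at a limit of this assay rather than at a number, sitting at the limit of >= 20 ug/mL in this assay, at which 1 of the 3 values shown sits, with its result recorded as >= 20 ug/mL. Compound 4 `Cc1cc(-c2cccc([N+](=O)[O-])c2)cn2c(CSCCc3ccccc3)cnc12` differs from compound 2 by 3-nitrophenyl in place of 4-cyanophenyl on an aromatic carbon. Among the compounds with values here, the one measured step exchanges a whole aryl group on an aromatic carbon and is beyond the scatter, but it does not involve a 4-cyanophenyl or a 3-nitrophenyl, so it bears only loosely here; the expected step is a step that the limit leaves unreadable from compound 2 to compound 4. Compound 4 is therefore estimated to give 40 ug/mL, within 20 ug/mL to 100 ug/mL.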

Compound 4, minimum cytotoxic concentration: >= 100 ug/mL
Compound 4: no number, only a limit; the forecaster's own chance of this, stated with the estimate: 50%; at least 2.5-fold (0.39 log units) between middle value and limit.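

In this assay compound 4 gives >= 100 ug/mL, a limit and not a number. Going by these compounds alone, compound 2 gives >= 20 ug/mL, also a limit, so no step from compound 2 to compound 4 can be read. The compounds shown leave open whether 3-nitrophenyl or 4-cyanophenyl gives the higher number.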